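Five-heavy-atom group on the oxygen across two cores

This account rests on a few compounds, and the source may have more. Where it says the series, first, only, none or still open, it means among the compounds named here.

Measured so far:
compound 1 `COc1ccc(C2=C(c3cc(OC)c(OC)c(OC)c3)C(=O)C(O)C2)cc1`, > 100 ug/mL
compound 2 `COc1ccc(C2=C(c3cc(OC)c(OC)c(OC)c3)CC(O)C2=O)cc1[N+](=O)[O-]`, > 100 ug/mL
compound 3 `COc1ccc(C2=C(c3cc(OC)c(OC)c(OC)c3)C(=O)C(O[SiH2]C(C)(C)C)C2)cc1`, 28 ug/mL

In an ADME assay on DU-145 cells (Homo sapiens) for cytotoxicity, read by MTT assay, with a stated time of 72 h (a higher number here means a weaker inhibitor, a lower number a stronger inhibitor), compound 1 gives > 100 ug/mL, which is a limit of the assay and not a number. Compound 2 likewise gives only the limit > 100 ug/mL in this assay. Compound 3 gives 28 ug/mL. The change from compound 1 to compound 3 is a group of 5 heavy atoms (4 carbon, 1 silicon; no ring) in place of a hydrogen atom, on an oxygen on a saturated carbon; its step is an at least 3.5-fold lower number from compound 1 to compound 3 (0.55 log units; beyond the scatter). How the core of compound 2 differs from the core of compound 1 is not broken down here.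

Compound 4 `COc1ccc(C2=C(c3cc(OC)c(OC)c(OC)c3)CC(O[SiH2]C(C)(C)C)C2=O)cc1[N+](=O)[O-]` carries the same change on the core of compound 2: a group of 5 heavy atoms (4 carbon, 1 silicon; no ring) in place of a hydrogen atom, on an oxygen on a saturated carbon. Both places read the same, so the change is the same. Two of three values sit at the limit of > 100 ug/mL in this assay, at which 2 of the 3 values shown sit, so the earlier step is a floor only. Compound 4 is expected to move by an at least 2.5-fold lower number from compound 2 to compound 4 (0.39 log units; beyond the scatter), resting on the step from compound 1 to compound 3 an at least 3.5-fold lower number from compound 1 to compound 3 (0.55 log units; beyond the scatter). The estimate for compound 4 is 40 ug/mL.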

Compound 4, half-maximal inhibitory concentration: > 100 ug/mL
Compound 4 gave a limit, no number (the forecaster's own chance of this, stated with the estimate: 35%); at least 2.5-fold (0.39 log units) between middle value and limit.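

Compound 2 and compound 4 both stand only as limits of the assay, so no new step can be read from this pair: the limit of > 100 ug/mL in this assay, at which 3 of the 4 values shown sit.

As far as these compounds go, whether the change that gave an at least 3.5-fold lower number from compound 1 to compound 3 (0.55 log units; beyond the scatter) lowers the number at all on the core of compound 2 stays open.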